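The source may hold more compounds than are shown below. What is called first, only, known or untested is meant among the compounds shown, and "the series" means these compounds.

Compound 1, `COc1ccc(-c2cc(-c3cccn3C)c(C#N)c(=O)[nH]2)cc1OC`, gives 91200 nM in a functional assay on IGROV-1 cells (Homo sapiens) for inhibition, read by sulforhodamine B assay, with a stated time of 48 h; a higher number here means a weaker inhibitor of growth, a lower number a stronger inhibitor of growth.
Compound 2, `Cn1cccc1-c1cc(-c2cccs2)nc(N)c1C#N`, is reported in this assay only as a limit of the assay, > 100000 nM.
Compound 3, `Cn1cccc1-c1cc(-c2ccccc2)[nH]c(=O)c1C#N`, is likewise reported in this assay only as a limit of the assay, > 100000 nM.

Compound 2 therefore stands at the edge of what the measurement can report: no number is given for it, only the statement that growth inhibition was not reached within the tested range. For the measured compounds named here, this is the common situation here, as the limit of > 100000 nM in this assay, at which 2 of the 3 values shown sit, shows, and compound 1, the single compound with an actual number, is itself a weak inhibitor of growth.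

Compound 4, `Cn1cccc1-c1cc(-c2ccccc2)nc(N)c1C#N`, is the unmeasured compound. It differs from compound 2 by phenyl in place of thiophen-2-yl on an aromatic carbon. Going by the values given here, no pair of measured compounds that differ in a single place is available, so the effect of this exchange cannot be sized from the data. Against that background the expectation is a step of no size beyond the scatter, with a good chance that compound 4 again returns only a limit. The estimate for compound 4 is therefore 150000 nM, within a range from 50000 nM to 500000 nM, meaning a step that the limit leaves unreadable from compound 2 to compound 4 that is expected to be negligible.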

Compound 4, concentration for 50% growth inhibition: > 100000 nM
Compound 4: no number, only a limit (the forecaster's own chance of this, stated with the estimate: 80%); the middle value does not contradict the limit.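

Compound 2 and compound 4 are both reported in this assay only as limits of the assay, so the step from thiophen-2-yl to phenyl between them cannot be read. The compounds shown leave open how far any single change to the shared core moves growth inhibition, and most values sit at one limit: the limit of > 100000 nM in this assay, at which 3 of the 4 values shown sit.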